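Removing the Aryl Group from a Spiro Sigma-1 Ligand

A few compounds are considered here, and "the series" means these few. Any claim that something is new, unique, unknown or untested is made for them only; others in the source may bear on it.

Compound 1 `COC1Cc2sc(-c3ccc(-c4ccccc4)cc3)cc2C2(CCN(Cc3ccccc3)CC2)O1`: 220 nM
Compound 2 `COC1Cc2cc(-c3cccc4ccccc34)sc2C2(CCN(Cc3ccccc3)CC2)O1`: 12 nM
Compound 3 `COC1Cc2cc(-c3cccnc3)sc2C2(CCN(Cc3ccccc3)CC2)O1`: 2.5 nM

In an assay on membranes from brain for displacement of a labelled ligand from Sigma non-opioid intracellular receptor 1 (Cavia porcellus), read by scintillation counting, with a stated time of 120 min (a higher number here means a weaker inhibitor, a lower number a stronger inhibitor), compound 3 gives the lowest of the three numbers and so is the strongest inhibitor measured. For the measured compounds named here, the only single-point step, a 4.8-fold lower number from compound 2 to compound 3 (0.68 log units; beyond the scatter), shows that a smaller aromatic group at that carbon gave a stronger inhibitor. Compound 1 carries an even larger group but also differs elsewhere, so its weaker value is noted without drawing a step from it. Compound 4 `COC1Cc2ccsc2C2(CCN(Cc3ccccc3)CC2)O1` removes the group altogether: hydrogen in place of pyridin-3-yl on an aromatic carbon. Going by the values given here, no measured step removes a group entirely, so the direction is uncertain; the shrinking from compound 2 to compound 3 helped, which argues against a large loss. Compound 4 is expected to show the step of a 3.2-fold higher number from compound 3 to compound 4 (0.51 log units; beyond the scatter). Compound 4 is therefore estimated at 8 nM, between 1.5 nM and 40 nM.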

Compound 4, inhibition constant: 1.9 nM
Compound 4: the middle estimate sits 4.2-fold (0.62 log units) above what was measured; measured number inside the range.
By their numbers in this assay, from the lowest: compounds 4 and 3 (each within the scatter of the next); then compound 2; then compound 1.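

In this assay, an aromatic group on this carbon turns out not to be needed. Hydrogen and pyridin-3-yl cannot be told apart (a 1.3-fold lower number from compound 3 to compound 4 (0.12 log units; within the scatter)), whereas replacing naphthalen-1-yl with hydrogen gives a real gain (a 6.3-fold lower number from compound 2 to compound 4 (0.80 log units; beyond the scatter)). No measurement shown explains either result.

From the compounds shown here alone, what remains open is whether a non-aromatic group on this carbon, such as methyl, an amine or a carboxylic acid, would keep the number as low as hydrogen does.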